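Notes on compound 3 against the measured pair

This account rests on a few compounds, and the source may have more. Where it says the series, first, only, none or still open, it means among the compounds named here.

Measured in a functional assay on A 172 cells (Homo sapiens) for cytotoxicity, read by colorimetric assay and MTT assay; on this read-out higher numbers stand for weaker inhibition and lower numbers for stronger inhibition
- compound 1 `COc1cccc2cc(-c3ccccc3)c(O)nc12` gives 10000 nM
- compound 2 `COc1ccc(-c2cc3c(OC)cc(OC)cc3n(CCCC#N)c2=O)cc1` gives 10000 nM

Compound 2 stands level with compound 1 in this assay with no gap beyond the scatter. Compound 3 `COc1ccc(-c2cc3c(OC)cc(OC)cc3n(CCC(=O)OCc3ccccc3)c2=O)cc1` has not yet been measured. It differs from compound 2 by benzyloxycarbonyl in place of cyanomethyl on a saturated chain carbon, two bonds along the chain from an aromatic nitrogen and the same difference, cut one bond further out, reads 2-cyanoethyl to (benzyloxycarbonyl)methyl. For the measured compounds named here, no measured pair differs in one place, so this change has no direct precedent. Going by the values given here, the only anchor is compound 2 at 10000 nM in this assay and no step beyond the scatter is expected, in either direction. The estimated move is a 1.3-fold lower number from compound 2 to compound 3 (0.10 log units; within the scatter) and it stays within the scatter. Compound 3 is expected at 8000 nM with an estimated range of 3000 nM to 15000 nM as the working figure.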

Compound 3, half-maximal inhibitory concentration: 10000 nM
Beside the measured number, compound 3's estimate is 1.3-fold (0.10 log units) below it, and the stated range covers the measured number.
By their numbers in this assay, from the lowest: compounds 1, 2 and 3 (each within the scatter of the next).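

In this assay, for the compounds shown here, benzyloxycarbonyl in place of cyanomethyl on a saturated chain carbon, two bonds along the chain from an aromatic nitrogen, gives no change at the digits printed from compound 2 to compound 3 (within the scatter) and is the only single-place step so far. At this position, losing the nitrile and gaining a carbonyl and a six-membered aromatic ring of carbon only does not separate the two compounds in this assay. No available evidence bears on the reason for this result.

From the compounds shown here alone, whether a carboxylic acid, an amine or a longer chain at this position would separate from compound 2 remains open. With only this single-place step available, the compounds shown give no direction for changes at this position.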